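A fluorine added to the central ring of compound 1

The source may report more compounds than this note shows. Statements on the series, on what has been measured and on what is new or still open speak of the compounds shown alone.

Of the compounds shown here, three have been tested in a functional assay on HT-29 cells (Homo sapiens) for antiproliferative activity, read by MTT assay, with a stated time of 72 h; on this read-out lower numbers stand for stronger inhibition and higher numbers for weaker inhibition. Compound 1, with the structure `O=C(Nc1ccc(Oc2ccnc3[nH]ccc23)cc1)c1cc2cccnc2n(-c2ccccc2)c1=O`, gives 290 nM. Compound 2, `COc1ccc(-n2c(=O)c(C(=O)Nc3ccc(Oc4ccnc5[nH]ccc45)cc3)cc3cccnc32)cc1`, gives 1260 nM, and compound 3, `O=C(Nc1ccc(Oc2ccnc3[nH]ccc23)cc1)c1cc2cccnc2n(-c2ccc(F)c(Cl)c2)c1=O`, gives 560 nM. Compound 1 thus has the lowest number of the three: the step of a 1.9-fold higher number from compound 1 to compound 3 (0.29 log units; within the scatter) lies within the scatter, while a 4.3-fold higher number from compound 1 to compound 2 (0.64 log units; beyond the scatter) is beyond it, as is a 2.3-fold lower number from compound 2 to compound 3 (0.35 log units; beyond the scatter).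

Compound 4, `O=C(Nc1ccc(Oc2ccnc3[nH]ccc23)c(F)c1)c1cc2cccnc2n(-c2ccccc2)c1=O`, is not yet measured. It differs from compound 1 in one place: fluoro in place of hydrogen on an aromatic carbon. All three measured steps change the group on the aromatic nitrogen of the shared core, not the ring where the fluoro enters, so none of them speaks directly to this change. They only show that small changes on the periphery of compound 1 move this assay by modest amounts at most. Going by the values given here, a single fluoro is a small addition, and no measured step suggests a large shift in either direction.

Compound 4 is therefore expected to sit close to compound 1, with a step of about a 1.3-fold lower number from compound 1 to compound 4 (0.12 log units; within the scatter). The estimate for compound 4 in this assay is 220 nM, with a likely range from 80 nM to 600 nM.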

Compound 4, half-maximal inhibitory concentration: 160 nM
Compound 4: middle estimate off by 1.4-fold (0.14 log units), on the high side; low and high end bracket the measured number.
By their numbers in this assay, from the lowest: compounds 4, 1 and 3 (each within the scatter of the next, the first and the last beyond it); then compound 2.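

Going by these compounds alone, the fluoro gives the first reading on the six-membered carbon-only ring, where it stands ortho to one large group and meta to another; every earlier step changed the group on the aromatic nitrogen. In this assay, the change gives a 1.8-fold lower number from compound 1 to compound 4 (0.26 log units; within the scatter), so this assay cannot tell compound 4 from compound 1, and this position accepts one added fluorine atom without a change beyond the usual scatter. Nothing measured here explains how the fluoro acts at this position, so the result stands as an observation about antiproliferative activity alone.

The compounds shown leave open whether this position accepts anything larger than a fluoro, since a methyl group or an amine in the same place could give a very different result, and a single small atom says little about the limits of the position. They also leave open whether the fluoro would give a similar result with another group on the aromatic nitrogen, such as the 3-chloro-4-fluorophenyl group of compound 3 or the 4-methoxyphenyl group of compound 2.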